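The source may report more compounds than this note shows. Statements on the series, on what has been measured and on what is new or still open speak of the compounds shown alone.

Measured compounds:
compound 1 `Nc1ncnc2ncn(CCO)c12`, in an assay on CHO cells for displacement of a labelled ligand from adenosine receptor A1 (Homo sapiens) (on this read-out higher numbers stand for weaker inhibition and lower numbers for stronger inhibition), compound 1 gives > 100000 nM, a limit of the assay.
compound 2 `CC(O)Cn1cnc2ncnc(N)c21`, in this assay compound 2 gives > 100000 nM, again a limit.
compound 3 `Nc1ncnc2c1nc(Br)n2CCCO`, in this assay compound 3 gives 1000 nM.

Among the compounds with values here, compound 3 stands as the only real number in the set; the other two values are limits, as noted in the limit of > 100000 nM in this assay, at which 2 of the 3 values shown sit. Within the data shown here, the one step between measured neighbours, a step that the two limits leave unreadable from compound 1 to compound 2, cannot be read in size because both ends are limits, so it gives no scale for any substituent change on the chain.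

Compound 4 `Nc1ncnc2c1nc(Br)n2CC(O)CO` differs from compound 3 by hydroxy in place of hydrogen on a saturated chain carbon bound to two saturated chain carbons. Among the measured compounds shown here, no measured step touches a hydroxy added to the chain, and the methyl step from compound 1 to compound 2 is unreadable, so the only anchor is the value of compound 3 itself. A small polar addition of this kind is expected to leave the inhibition constant of compound 4 close to that of compound 3, with the step of a 1.5-fold higher number from compound 3 to compound 4 (0.18 log units; within the scatter) expected to stay within the scatter. Compound 4 is therefore estimated at 1500 nM, with a range from 500 nM to 5000 nM.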

Compound 4, inhibition constant: 16000 nM
Compound 4: middle estimate off by 11-fold (1.03 log units), on the low side, and the stated range ends below it.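

In this assay, within the data shown here, hydroxy in place of hydrogen on a saturated chain carbon bound to two saturated chain carbons gives a 16-fold higher number from compound 3 to compound 4 (1.20 log units; beyond the scatter), the first step in the set whose size can be read. This shows that the chain of compound 3 does not tolerate every small addition: going from 3-hydroxypropyl to 2,3-dihydroxypropyl clearly weakens inhibition, and a single added hydroxy is enough to do so. Among these compounds, the earlier compounds could not show this, since their only step, on the shorter chain, cannot be read and so gave no measure of how much a change on the chain matters.

Going by these compounds, it remains open whether the weakening belongs to hydroxy itself or would also follow from another group on the same carbon, such as an amine or a methoxy, and whether a longer chain carrying the same hydroxy would behave alike. Compound 1 and compound 2 give only limits, so neither offers a number to set beside this step: the limit of > 100000 nM in this assay, at which 2 of the 4 values shown sit.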